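Biphenyl Replaces Pyridine Where Only Limits Are Seen

The source may report more compounds than this note shows. Statements on the series, on what has been measured and on what is new or still open speak of the compounds shown alone.

Compound 2 `CCOC(=O)CCCCCOc1cccc(CN(C(=O)c2ccc(-c3ccncc3)cc2)C(C)C)c1` gives in an ADME assay on HEK293 cells (Homo sapiens) for cytotoxicity, read by CellTiter-Glo and resazurin assay, with a stated time of 72 h (on this read-out lower numbers stand for an effect already at smaller amounts and higher numbers for an effect only at larger amounts of compound), only a limit, > 26000 nM. Compound 1 `CCOC(=O)CCCCCOc1cccc(CN(C(=O)c2ccc(-c3cccc(N(C)C)c3)cc2)C(C)C)c1` likewise reaches only a limit, > 26000 nM. The step that the two limits leave unreadable from compound 1 to compound 2 therefore cannot be read, since both values sit at the limit of > 26000 nM in this assay, at which 2 of the 2 values shown sit. Compound 3 `CCOC(=O)CCCCCOc1cccc(CN(C(=O)c2ccc(-c3cccc(-c4ccccc4)c3)cc2)C(C)C)c1` carries 3-phenylphenyl in place of pyridin-4-yl on an aromatic carbon. Among the compounds with values here, no measured step gives a readable size or direction for this change, so no movement beyond the scatter in this assay is expected. For compound 3 the estimated step of a number no higher from compound 2 to compound 3 (the limit leaves the size open) is accordingly small. Compound 3 is expected to give 26000 nM, within a range from 8000 nM to 80000 nM, most likely again only as a limit.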

Compound 3, half-maximal effective concentration: > 26000 nM
Compound 3: a limit, no number; the forecaster's own chance of this, stated with the estimate: 65%; the middle value sits exactly at the limit.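

In this assay, within the data shown here, compound 3 also gives only a limit, > 26000 nM and so no step among compound 1, compound 2 and compound 3 can be read. The compounds shown leave open where any of the three would reach a half-maximal effect, and whether these changes shift it at all.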